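Fluoro for methyl on the 4-methylphenyl group

A few compounds are considered here, and "the series" means these few. Any claim that something is new, unique, unknown or untested is made for them only; others in the source may bear on it.

Measured in a functional assay on HeLa cells (Homo sapiens) for antiproliferative activity, read by MTT assay, with a stated time of 24 h; a lower number here means a stronger inhibitor, a higher number a weaker inhibitor:
- compound 1 `Cc1ccc(-c2nn(-c3ccccc3)cc2-c2nc3ccccc3n2S(=O)(=O)c2cc(C)ccc2C)cc1`: 370 nM
- compound 2 `Cc1ccc(-c2nn(-c3ccccc3)cc2-c2nc3ccccc3n2S(=O)(=O)c2ccc(Cl)cc2)cc1`: 4060 nM
- compound 3 `Cc1ccc(-c2nn(-c3ccccc3)cc2-c2nc3ccccc3n2S(=O)(=O)c2ccc(C(F)(F)F)cc2)cc1`: 1520 nM

In this assay compound 1 has the lowest of the three numbers, with compound 3 nearest and compound 2 furthest. Compound 4 `Cc1ccc(C)c(S(=O)(=O)n2c(-c3cn(-c4ccccc4)nc3-c3ccc(F)cc3)nc3ccccc32)c1` is not yet measured. It differs from compound 1 by fluoro in place of methyl on an aromatic carbon, para to a large group, so 4-methylphenyl becomes 4-fluorophenyl.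

For the measured compounds named here, no measured step touches that place. Two steps replace the whole group on the sulfonyl sulfur: an 11-fold higher number from compound 1 to compound 2 (1.04 log units; beyond the scatter) and a 4.1-fold higher number from compound 1 to compound 3 (0.61 log units; beyond the scatter). The closest in kind is a single swap on an aromatic carbon, a 2.7-fold lower number from compound 2 to compound 3 (0.43 log units; beyond the scatter), though on a different group. A modest step is therefore expected, not a large one. The direction is a weak guess towards a higher number: compound 1 at 370 nM is the lowest so far. The expected step is a 1.6-fold higher number from compound 1 to compound 4 (0.21 log units; within the scatter). Compound 4 is estimated at 600 nM, with an expected range of 200 nM to 1800 nM.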

Compound 4, half-maximal inhibitory concentration: 320 nM
Beside the measured number, compound 4's estimate is 1.9-fold (0.27 log units) above it; the measured number falls inside the stated range.
By their numbers in this assay, from the lowest: compounds 4 and 1 (each within the scatter of the next); then compound 3; then compound 2.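

In this assay, the change from 4-methylphenyl to 4-fluorophenyl gives a 1.2-fold lower number from compound 1 to compound 4 (0.06 log units; within the scatter), so at this place on the aromatic ring fluoro and methyl cannot be told apart. The earlier steps shown here all changed the group on the sulfonyl sulfur or a group on its aromatic ring, and each lay beyond the scatter, whereas this first change at the 4-methylphenyl group does not. No measurement shown here offers an explanation for this result.

On these data alone, whether this place accepts groups other than these two remains open: a methoxy, an amine, a carboxylic acid or a longer chain would test that. Also open, as far as these compounds go, is whether fluoro for methyl stays within the scatter when the sulfonyl sulfur carries 4-chlorophenyl or 4-(trifluoromethyl)phenyl, as in compound 2 and compound 3.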